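A few compounds are considered here, and "the series" means these few. Any claim that something is new, unique, unknown or untested is made for them only; others in the source may bear on it.

Compound 1 `COc1cc(COc2ccc(C(=O)NN)cc2)cc(OC)c1OC` is the parent hydrazide; in a physicochemical assay, with a stated time of 30 min (on this read-out lower numbers stand for stronger inhibition and higher numbers for weaker inhibition), compound 1 gives 264 ug/mL. Compound 2 `COc1cc(COc2ccc(C(=O)N/N=C/c3ccc(OC)c(OC)c3OC)cc2)cc(OC)c1OC` returns only a limit, and compound 2 gives > 100 ug/mL. Compound 3 `COc1cc(COc2ccc(C(=O)N/N=C/c3cccc(O)c3)cc2)cc(OC)c1OC` likewise returns only a limit, and compound 3 gives > 100 ug/mL. Compound 3 therefore stands at the limit of > 100 ug/mL in this assay, at which 2 of the 3 values shown sit. Compound 4 `COc1cc(COc2ccc(C(=O)N/N=C/c3ccccc3O)cc2)cc(OC)c1OC` differs from compound 3 by 2-hydroxyphenyl in place of 3-hydroxyphenyl on a carbon with a double bond to nitrogen. Among the measured compounds shown here, the only measured steps touching compound 3 are a step that the limit leaves unreadable from compound 1 to compound 3 and a step that the two limits leave unreadable from compound 2 to compound 3, and both are left unreadable by the limits, so they give no size for the change to compound 4. Compound 4 is therefore expected to remain at the limit, with an expected step that the limit leaves unreadable from compound 3 to compound 4 within the scatter. Compound 4 is estimated at 150 ug/mL, between 70 ug/mL and 400 ug/mL.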

Compound 4, half-maximal inhibitory concentration: > 100 ug/mL
Compound 4 was reported as a limit; the forecaster's own chance of this, stated with the estimate: 80%; the middle value lies beyond the limit too.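

Compound 4 also returns only a limit, so no step to it from compound 1, compound 2 or compound 3 can be read: the limit of > 100 ug/mL in this assay, at which 3 of the 4 values shown sit.

The compounds shown leave open how far compound 2, compound 3 and compound 4 differ from one another or from compound 1.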